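A few compounds are considered here, and "the series" means these few. Any claim that something is new, unique, unknown or untested is made for them only; others in the source may bear on it.

In a functional assay on DU-145 cells (Homo sapiens) for inhibition, read by trypan blue exclusion, with a stated time of 96 h (a higher number here means a weaker inhibitor of growth, a lower number a stronger inhibitor of growth), compound 1 (`O=C(/C(=C\c1ccc(Cl)cc1)S(=O)(=O)c1ccc(Br)cc1)c1ccc(Br)cc1`) gives 50000 nM as the highest of three numbers. Compound 2 (`CSc1ccc(/C=C(\C(=O)c2ccc(Cl)cc2)S(=O)(=O)Cc2ccc(C)cc2)cc1`) gives 10000 nM and compound 3 (`O=C(/C(=C\c1ccc(Br)cc1)Sc1ccc(Br)cc1)c1ccc(Br)cc1`) gives 1000 nM as its lowest, both lower than compound 1 beyond the scatter. These three differ in more than one place, so no single change can be read from them. Compound 4 (`O=C(/C(=C\c1csc([N+](=O)[O-])c1)S(=O)(=O)c1ccc(Br)cc1)c1ccc(Br)cc1`) carries 5-nitrothiophen-3-yl in place of 4-chlorophenyl on a double-bonded chain carbon bound to a double-bonded chain carbon and otherwise keeps the core of compound 1. Compound 1 at 50000 nM stands at the top of this small range, so a downward step beyond the scatter is expected. In this assay the estimated change is a 5.0-fold lower number from compound 1 to compound 4 (0.70 log units; beyond the scatter) for this replacement. For compound 4 the estimated value is 10000 nM with 2000 nM to 50000 nM as the expected range.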

Compound 4, concentration for 50% growth inhibition: 1000 nM
Compound 4: middle estimate off by 10-fold (1.00 log units), on the high side, outside the stated range (below it).
By their numbers in this assay, from the lowest: compounds 3 and 4 (each within the scatter of the next); then compound 2; then compound 1.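

In this assay, within the data shown here, the place on a double-bonded chain carbon bound to a double-bonded chain carbon responds strongly to the group it carries: 5-nitrothiophen-3-yl in place of 4-chlorophenyl gives a 50-fold lower number from compound 1 to compound 4 (1.70 log units; beyond the scatter) as the only single change that can be read here. Nothing available explains the size of this step.

With one change at this place, the nitro group and the thiophene ring cannot be told apart. As far as these compounds go, whether unsubstituted thiophen-3-yl, 4-nitrophenyl or an amine on the thiophene would retain the step remains open.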